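Working notes: methoxy in place of methyl

The source may report more compounds than this note shows. Statements on the series, on what has been measured and on what is new or still open speak of the compounds shown alone.

- compound 1 `Cc1ccc(C(=O)/C=C/c2cc(O)nc(O)n2)cc1` gives 182000 nM
- compound 2 `OCCOCn1cnc2c(S)nc(F)nc21` gives 170000 nM

In an ADME assay on L1210/0 cells (Mus musculus) for cytotoxicity, with a stated time of 48 h (on this read-out higher numbers stand for weaker inhibition and lower numbers for stronger inhibition), compound 1 and compound 2 lie within the scatter of each other, so neither stands apart. Compound 3 `COc1ccc(C(=O)/C=C/c2cc(O)nc(O)n2)cc1` carries one change on the core of compound 1: methoxy in place of methyl on an aromatic carbon, para to a large group (methoxy in place of methyl on an aromatic carbon). Among the measured compounds shown here, no measured pair differs in one place, so no step beyond the scatter is expected in this assay in either direction. The expected 1.2-fold lower number from compound 1 to compound 3 (0.08 log units; within the scatter) stays within the scatter. For compound 3 the expected value is 150000 nM (estimated range 60000 nM to 300000 nM).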

Compound 3, half-maximal inhibitory concentration: > 200000 nM
Compound 3: a limit, no number; the forecaster's own chance of this, stated with the estimate: 10%; middle value at least 1.3-fold (0.12 log units) from the limit.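

In this assay compound 3 gives > 200000 nM, which is a limit of the assay and not a number. Methoxy in place of methyl at this position gives an at least 1.0-fold higher number from compound 1 to compound 3 (0.04 log units; that floor lies within the scatter), so the change brings no lower number on the core of compound 1. How far the step reaches cannot be read because the value of compound 3 stops at a limit: the limit of > 200000 nM in this assay, at which 1 of the 3 values shown sits.

The compounds shown leave open whether an amine or a carboxylic acid at this position would give a lower number than compound 1.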